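Piperidine ring returns with a reversed amide: compound 3

A few compounds are considered here, and "the series" means these few. Any claim that something is new, unique, unknown or untested is made for them only; others in the source may bear on it.

Measured: compound 1 `COc1ccccc1-c1csc2cnc(Nc3ccc(NC(=O)[C@@H]4CCCNC4)cc3)nc12` and compound 2 `COc1ccccc1-c1csc2cnc(Nc3ccc(NC(=O)CN)cc3)nc12`.

In a functional assay on A549 cells (Homo sapiens) for inhibition, read by MTT assay, with a stated time of 72 h (on this read-out lower numbers stand for stronger inhibition and higher numbers for weaker inhibition), compound 1 gives 410 nM and compound 2 gives 1950 nM, the higher of the two numbers. Among the compounds with values here, the one step between them is a 4.8-fold higher number from compound 1 to compound 2 (0.68 log units; beyond the scatter). Compound 3 `COc1ccccc1-c1csc2cnc(Nc3ccc(C(=O)NC4CCNCC4)cc3)nc12` differs from compound 2 by (piperidin-4-yl)carbamoyl in place of ((aminomethyl)carbonyl)amino on an aromatic carbon. On these data alone, that step bears only in part: piperidin-3-yl in place of aminomethyl gave the lower number, while a carbonyl linked the other way round is untested. A downward step is expected, and the step expected is a 3.0-fold lower number from compound 2 to compound 3 (0.48 log units; beyond the scatter). Compound 3 is estimated at 650 nM, range 160 nM to 2600 nM.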

Compound 3, half-maximal inhibitory concentration: 360 nM
The estimate for compound 3 lay 1.8-fold (0.26 log units) above the measured number; the measured number falls inside the stated range.
By their numbers in this assay, from the lowest: compounds 3 and 1 (each within the scatter of the next); then compound 2.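

In this assay the (piperidin-4-yl)carbamoyl group on this aromatic carbon gives a 5.4-fold lower number from compound 2 to compound 3 (0.73 log units; beyond the scatter) and thus carries a six-membered non-aromatic ring with the carbonyl linked the other way round. Against the ((piperidin-3-yl)carbonyl)amino group of compound 1, the change gives a 1.1-fold lower number from compound 1 to compound 3 (0.06 log units; within the scatter) and does not separate the two groups. Nothing at hand explains either result. On these data alone, the effect of amide direction alone stays open, since the ring attachment point changes with it; the ((piperidin-4-yl)carbonyl)amino group would isolate it. As far as these compounds go, whether the ring nitrogen matters also stays open, and a cyclohexyl amide would address that.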